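A few compounds are considered here, and "the series" means these few. Any claim that something is new, unique, unknown or untested is made for them only; others in the source may bear on it.

Compound 1 `CCOC(=O)c1cccc(-c2ccc(OC)cc2)c1` gives 80000 nM in an assay on COS-7 cells for inhibition of patatin-like phospholipase domain-containing protein 2 (Mus musculus); on this read-out lower numbers stand for stronger inhibition and higher numbers for weaker inhibition. Compound 2 `CCOC(=O)c1cccc(-c2ccc(OCC)nc2)c1` gives 130000 nM in this assay. Compound 3 `CCOC(=O)c1cccc(-c2cccs2)c1` gives 90000 nM in this assay.

All three compounds share the same core and differ only in the aromatic group attached to it; all three are weak inhibitors. Compound 1 has the lowest of the three numbers in this assay, but its gaps to compound 3 and to compound 2 both lie within the usual scatter of the measurement, so no real order among the three can be read from these values.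

Compound 4 `CCOC(=O)c1cccc(-c2ccc(CN3CCCC3)cc2)c1` has not yet been measured. It differs from compound 1 in one place: (pyrrolidin-1-yl)methyl in place of methoxy on an aromatic carbon, para to a large group. Among the compounds with values here, no measured pair shows what this exchange does, so there is no step to lean on. With the three known compounds so close together, a modest change in either direction is as plausible as none beyond the scatter. Compound 4 is expected to come out at 60000 nM, within a range from 15000 nM to 200000 nM, which would correspond to an estimated step of a 1.3-fold lower number from compound 1 to compound 4 (0.12 log units; within the scatter).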

Compound 4, half-maximal inhibitory concentration: > 200000 nM
Compound 4 ended at the assay's limit; the forecaster's own chance of this, stated with the estimate: 15%; middle value at least 3.3-fold (0.52 log units) from the limit.
By their numbers in this assay, from the lowest: compounds 1, 3 and 2 (each within the scatter of the next). At a limit, above all of these: compound 4.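

In this assay compound 4 gives > 200000 nM, and this value is a limit of the assay, not a number. The earlier compounds shown here all lay within the scatter of one another and offered no measured step, but this exchange of methoxy for (pyrrolidin-1-yl)methyl on an aromatic carbon, para to a large group, gives an at least 2.5-fold higher number from compound 1 to compound 4 (0.39 log units; beyond the scatter), so what sits at this place can weaken inhibition beyond the scatter. This is a single pair, and its step only sets a minimum for the size of the change, with the true size out of reach: the limit of > 200000 nM in this assay, at which 1 of the 4 values shown sits.

The exchange alters several things at once, since the entering group brings more heavy atoms, a five-membered non-aromatic ring and a nitrogen in place of an oxygen, and the compounds shown cannot say which of these goes with the weaker inhibition. Going by these compounds, a butyl chain, which has no nitrogen, or an open-chain dimethylaminomethyl group, which has no ring, at the same place would help pull these apart, and whether any group here gives stronger inhibition than methoxy remains open.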